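Removing a Bromoacrylamide Warhead from Two Chalcone Amides

The source may hold more compounds than are shown below. What is called first, only, known or untested is meant among the compounds shown, and "the series" means these compounds.

Measured compounds:
compound 1, `C=C(Br)C(=O)Nc1ccc(/C=C/C(=O)c2ccc(OC)cc2)cc1`, 1200 nM;
compound 2, `C=C(Br)C(=O)Nc1ccc(C(=O)/C=C/c2ccccc2)cc1`, 690 nM;
compound 3, `COc1ccc(C(=O)/C=C/c2ccc(N)cc2)cc1`, 282000 nM.

In a functional assay on FM3A cells (Mus musculus) for antiproliferative activity, with a stated time of 48 h (on this read-out lower numbers stand for stronger inhibition and higher numbers for weaker inhibition), compound 1 gives 1200 nM and compound 2 gives 690 nM; these two values lie within the scatter of each other. Compound 3 gives 282000 nM. The change from compound 1 to compound 3 is hydrogen in place of (1-bromoethenyl)carbonyl on a nitrogen on an aromatic ring, and its step is a 240-fold higher number from compound 1 to compound 3 (2.37 log units; beyond the scatter).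

Compound 4, `Nc1ccc(C(=O)/C=C/c2ccccc2)cc1`, has not yet been measured. For the measured compounds named here, it differs from compound 2 by hydrogen in place of (1-bromoethenyl)carbonyl on a nitrogen on an aromatic ring, the same change as the one from compound 1 to compound 3, at a place described in the same words. How the core of compound 2 differs from the core of compound 1 is not broken down here.

Because the step of a 240-fold higher number from compound 1 to compound 3 (2.37 log units; beyond the scatter) was large, the expected step from compound 2 to compound 4 in this assay is a 230-fold higher number from compound 2 to compound 4 (2.37 log units; beyond the scatter), of a similar size. Compound 4 is therefore estimated at 160000 nM, with a likely range from 40000 nM to 600000 nM.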

Compound 4, half-maximal inhibitory concentration: 34000 nM
Estimate against measurement, compound 4: 4.7-fold (0.67 log units) above, outside the stated range (below it).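

In this assay, replacing the (1-bromoethenyl)carbonyl group with hydrogen on the nitrogen again weakens inhibition strongly, with a 49-fold higher number from compound 2 to compound 4 (1.69 log units; beyond the scatter), so the direction of the change carries over to the second core. Its size does not carry over, since the two steps differ by more than the usual scatter: the same change on two cores in this assay, a 240-fold higher number (2.37 log units; beyond the scatter) from compound 1 to compound 3 and a 49-fold higher number (1.69 log units; beyond the scatter) from compound 2 to compound 4, 4.8-fold (0.68 log units) apart, beyond the scatter of two such steps. For this series, the change can therefore be expected to give a large loss on these two cores, but a step measured on one core is not an exact forecast for the other, and this pair of steps cannot show why the sizes differ or what would happen on a third core.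

The compounds shown leave open how much of each step belongs to the bromine and how much to the rest of the group. An acetyl group on the same nitrogen, or a propenoyl group with hydrogen in place of the bromine, would help to separate those two parts.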